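The source may hold more compounds than are shown below. What is called first, only, known or untested is meant among the compounds shown, and "the series" means these compounds.

Working notes on the series. Three compounds share one core and have numbers in an assay on isolated protein for inhibition of DNA topoisomerase 1 (Homo sapiens), with a stated time of 30 min, tested at 100 uM; on this read-out higher numbers stand for a stronger effect at the one concentration tested and lower numbers for a weaker effect. Compound 1 `Oc1cccc(-c2cc(-c3ccsc3)cc(-c3ccccc3O)n2)c1` gives 10.2%. Compound 2 `Oc1cccc(-c2cc(-c3ccsc3)cc(-c3cccc(O)c3)n2)c1` gives 59.2%. Compound 3 `Oc1ccc(-c2cc(-c3ccsc3)cc(-c3cccc(O)c3)n2)cc1` gives 17.1%. Compound 2 stands highest of the three: the step of a number 49 percentage points higher from compound 1 to compound 2 (beyond the scatter) and the step of a number 42.1 percentage points lower from compound 2 to compound 3 (beyond the scatter) both lie beyond the scatter, while the step of a number 6.9 percentage points higher from compound 1 to compound 3 (within the scatter) stays within it. All three measured steps concern only the position of the hydroxy group on one of the two phenyl rings; the thiophen-3-yl group is the same in every measured compound.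

Compound 4 `Oc1cccc(-c2cc(-c3ccccn3)cc(-c3cccc(O)c3)n2)c1` is not yet measured. It differs from compound 2 in one place: pyridin-2-yl in place of thiophen-3-yl on an aromatic carbon. Among the measured compounds shown here, no measured step touches this position, so no step on record bears directly on the change. The expectation therefore rests on compound 2 alone, with both 3-hydroxyphenyl groups kept as in compound 2, and in this assay compound 2 gives 59.2%. The number for compound 4 in this assay is expected to stay in that region, with a wide range. The expected step is a number 11.2 percentage points lower from compound 2 to compound 4 (beyond the scatter), not clearly beyond the scatter in either direction. Compound 4 is estimated at 48%, between 15% and 78%.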

Compound 4, a percentage reported as inhibition, at one concentration (the size of the read-out at that concentration, not a potency): 8.3%
The estimate for compound 4 lay 39.7 percentage points above the measured number, and the stated range ends above it.
By their numbers in this assay, from the lowest: compounds 4, 1 and 3 (each within the scatter of the next); then compound 2.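

The position opposite the ring nitrogen, the same in all earlier compounds, proves able to carry a large change in this assay: with both 3-hydroxyphenyl groups kept, the result is a number 50.9 percentage points lower from compound 2 to compound 4 (beyond the scatter). The number therefore depends on the aromatic group at this position as well as on where the hydroxy group sits, and this exchange of groups is a large step, as is a number 42.1 percentage points lower from compound 2 to compound 3 (beyond the scatter) on the hydroxy side. No measurement on record accounts for the drop.

With a single exchange at this position, the compounds shown cannot separate what is specific to leaving thiophen-3-yl from what is specific to pyridin-2-yl entering; plain phenyl, furan-3-yl or pyridin-3-yl at the same place would help draw that line. On these data alone, it also remains open whether pyridin-2-yl gives a similar step when paired with the hydroxyphenyl arrangements of compound 1 or compound 3, and so whether the two positions act independently or together.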